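Working notes: compound 2 to compound 3

The source may hold more compounds than are shown below. What is called first, only, known or untested is meant among the compounds shown, and "the series" means these compounds.

Measured in an ADME assay for permeability, using PAMPA, with a stated time of 4 h, at pH 5.5; a lower number here means that the compound crosses the layer more slowly, a higher number that the compound crosses the layer faster:
- compound 1 `CN(CCCCN(C[C@H]1Cc2ncccc2CN1)[C@H]1CCCc2cccnc21)C1CCOCC1`: 15 nm/s
- compound 2 `c1cnc2c(c1)CN[C@@H](CN(CCCCNC1COC1)[C@H]1CCCc3cccnc31)C2`: 7 nm/s

Compound 2 holds the lower of the two numbers, at 7 nm/s. The gap to the other measured compound is beyond the scatter: a 2.1-fold lower number from compound 1 to compound 2 (0.33 log units; beyond the scatter).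

The change under consideration leads to compound 3 `c1cnc2c(c1)CN[C@@H](CN(CCCC1CCNCC1)[C@H]1CCCc3cccnc31)C2`: piperidin-4-yl in place of ((oxetan-3-yl)amino)methyl on a saturated chain carbon, three bonds along the chain from an amine nitrogen. In words, piperidin-4-yl stands in place of ((oxetan-3-yl)amino)methyl on a saturated chain carbon, three bonds along the chain from an amine nitrogen.

Going by the values given here, only one measured step bears on this change, the modest one above, which also exchanges a group on a saturated chain. Among the compounds with values here, it is a loose guide, since no measured compound carries piperidin-4-yl. A step of similar modest size is therefore expected in this assay, tentatively towards a lower number, although the data do not settle the direction. The expected step is a 2.3-fold lower number from compound 2 to compound 3 (0.37 log units; beyond the scatter). Compound 3 is expected at 3 nm/s, with an estimated range of 1 nm/s to 10 nm/s.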

Compound 3, apparent permeability: 14 nm/s
Compound 3: the middle estimate sits 4.7-fold (0.67 log units) below what was measured; the whole stated range lies below it.
By their numbers in this assay, from the lowest: compounds 2, 3 and 1 (each within the scatter of the next, the first and the last beyond it).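

In this assay, piperidin-4-yl in place of ((oxetan-3-yl)amino)methyl on a saturated chain carbon, three bonds along the chain from an amine nitrogen, gives a step within the scatter (a 2.0-fold higher number from compound 2 to compound 3 (0.30 log units; within the scatter)), and the same group in place of (methyl(oxan-4-yl)amino)methyl does likewise (a 1.1-fold lower number from compound 1 to compound 3 (0.03 log units; within the scatter)). Piperidin-4-yl therefore cannot be separated from either of the other groups at this position, and the earlier step from compound 1 to compound 2 does not extend into a general downward trend: compound 3 goes against one, and that earlier step remains the only one beyond the scatter. Nothing available accounts for these readings.

The compounds shown leave open how this position would read with 1-methylpiperidin-4-yl, which would show whether a methyl on the piperidine nitrogen alters the number. They also leave open how an open-chain dimethylamino group, a carboxylic acid or a longer chain would read in this assay, so the range of groups tolerated here remains undefined.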